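Aryl variation on the saturated ring carbon: working notes

The source may report more compounds than this note shows. Statements on the series, on what has been measured and on what is new or still open speak of the compounds shown alone.

Compounds measured so far:
compound 1 `COc1cc(N2C(N)=C(C#N)C(c3ccc(Cl)cc3Cl)C3=C2CC(C)(C)CC3=O)cc(OC)c1OC`: 100%
compound 2 `COc1cc(N2C(N)=C(C#N)C(c3ccc(C)cc3)C3=C2CC(C)(C)CC3=O)cc(OC)c1OC`: 90%
compound 3 `COc1cc(N2C(N)=C(C#N)C(c3ccccc3)C3=C2CC(C)(C)CC3=O)cc(OC)c1OC`: 10%

In a functional assay on Ehrlich cells (Mus musculus) for cytotoxicity, tested at 100 ug/mL (on this read-out lower numbers stand for a weaker effect and higher numbers for a stronger effect at the one concentration tested), the number for compound 1 is the highest of the three, with compound 2 nearest a number 10 percentage points lower from compound 1 to compound 2 (within the scatter) and compound 3 furthest a number 90 percentage points lower from compound 1 to compound 3 (beyond the scatter). Compound 4 `COc1cc(N2C(N)=C(C#N)C(c3ccc(O)cc3)C3=C2CC(C)(C)CC3=O)cc(OC)c1OC` is not yet measured; its change from compound 1 is 4-hydroxyphenyl in place of 2,4-dichlorophenyl on a saturated ring carbon. Both steps from compound 1 bear on this: one small, one large. The step of a number 80 percentage points lower from compound 2 to compound 3 (beyond the scatter) shows that an aromatic ring without a substituent gives the weak number, whereas compound 1 and compound 2 both carry a substituted ring. Compound 4 keeps a substituted ring but of a kind not yet seen here, so a step down of moderate size is expected, a number 40 percentage points lower from compound 1 to compound 4 (beyond the scatter). Compound 4 is therefore estimated at 60%, between 15% and 100%.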

Compound 4, a percentage reported as activity, at one concentration (the size of the read-out at that concentration, not a potency): 100%
For compound 4 the middle estimate is 40 percentage points below the measured one; low and high end bracket the measured number.
By their numbers in this assay, from the lowest: compound 3; then compounds 2, 1 and 4 (each within the scatter of the next).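

In this assay, 4-hydroxyphenyl on the saturated ring carbon stands level with 2,4-dichlorophenyl (no change at the digits printed from compound 1 to compound 4 (within the scatter)) and with 4-methylphenyl (a number 10 percentage points higher from compound 2 to compound 4 (within the scatter)), so a hydroxy substituent serves here as well as chlorine or methyl. Hydroxy in place of hydrogen on the aromatic carbon (a number 90 percentage points higher from compound 3 to compound 4 (beyond the scatter)) leaves the phenyl of compound 3 alone at the low end of these four compounds. No available evidence explains why these different substituents give such similar numbers.

As far as these compounds go, whether an amine or a carboxylic acid on the aromatic ring would hold the number stays open. With one concentration, near the top of the scale, compound 1, compound 2 and compound 4 cannot be told apart in potency.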